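The source may report more compounds than this note shows. Statements on the series, on what has been measured and on what is new or still open speak of the compounds shown alone.

Measured so far in a functional assay on KBVIN cells (Homo sapiens) for cytotoxicity, read by MTT assay, with a stated time of 72 h; on this read-out higher numbers stand for an effect only at larger amounts of compound and lower numbers for an effect already at smaller amounts:
compound 1 `COc1ccc(Nc2cc(C3CCCCC3)oc(=O)c2)cc1` gives 4.39 uM
compound 2 `COc1ccc(Nc2cc(-c3ccc4ccccc4c3)oc(=O)c2)cc1` gives 0.13 uM
compound 3 `O=c1cc(NC2CCCCC2)cc(-c2ccccc2)o1` gives 9.15 uM

Compound 1 stands second highest of the three numbers. Compound 3 is nearest to it, with a higher number by a margin beyond the scatter, and compound 2 is furthest, with a far lower number. Compound 4 `CCCCCc1cc(Nc2ccc(OC)cc2)cc(=O)o1` is not yet measured and differs from compound 1 in one place: pentyl in place of cyclohexyl on an aromatic carbon. Within the data shown here, no step between measured compounds matches this change, so the expectation rests on compound 1 alone. The leaving and entering groups are close in heavy-atom count, and only a small step is expected for a 1.4-fold higher number from compound 1 to compound 4 (0.14 log units; within the scatter) in this assay, toward a higher number or none beyond the scatter. Compound 4 is estimated at 6 uM, in a range from 2 uM to 18 uM.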

Compound 4, concentration for half-maximal effect: 4.84 uM
Compound 4: middle estimate off by 1.2-fold (0.09 log units), on the high side; low and high end bracket the measured number.
By their numbers in this assay, from the lowest: compound 2; then compounds 1, 4 and 3 (each within the scatter of the next, the first and the last beyond it).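

Swapping cyclohexyl for pentyl on this aromatic carbon next to the ring oxygen gives a 1.1-fold higher number from compound 1 to compound 4 (0.04 log units; within the scatter) in this assay. At this position, then, the open chain and the six-membered carbon ring cannot be told apart in this assay, so the ring is not required to hold a number of this size. No measurement at hand bears on why the two groups read alike.

Still open, from the compounds shown here alone, is how far this tolerance extends: whether a methyl group or a longer chain such as octyl reads the same, and whether a terminal amine on the pentyl chain is accepted.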